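Swapping halogens on the sulfonyl aryl ring

This account rests on a few compounds, and the source may have more. Where it says the series, first, only, none or still open, it means among the compounds named here.

Two measured compounds share one core and differ only in the aryl ring on the sulfonyl sulfur. Compound 1 `CC1CCN(C2CCN(S(=O)(=O)c3ccc(Br)c(Cl)c3)CC2)CC1` gives 12 nM in a functional assay on DLD-1 cells (Homo sapiens) for antiproliferative activity, read by CellTiter-Glo, with a stated time of 72 h; on this read-out lower numbers stand for stronger inhibition and higher numbers for weaker inhibition. Among the measured compounds shown here, compound 2 `CC1CCN(C2CCN(S(=O)(=O)c3cccc(Br)c3)CC2)CC1` gives 3.2 nM in this assay, the lowest of the two numbers, and the single measured step, a 3.8-fold lower number from compound 1 to compound 2 (0.57 log units; beyond the scatter), shows how far a change of halogen pattern on this ring has moved the read-out so far. Compound 3 `CC1CCN(C2CCN(S(=O)(=O)c3ccc(F)cc3F)CC2)CC1` is not yet measured; it differs from compound 2 by 2,4-difluorophenyl in place of 3-bromophenyl on a sulfonyl sulfur. For the measured compounds named here, the only step that bears on this is a 3.8-fold lower number from compound 1 to compound 2 (0.57 log units; beyond the scatter), a modest one from a change of the same kind at the same place. Its direction cannot simply be carried over, as compound 3 alters the ring differently. A step of similar size, more likely toward a higher number, is expected, namely a 2.5-fold higher number from compound 2 to compound 3 (0.40 log units; beyond the scatter). Compound 3 is estimated at 8 nM, within 2 nM to 40 nM.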

Compound 3, half-maximal inhibitory concentration: 102 nM
For compound 3 the middle estimate is 13-fold (1.11 log units) below the measured one, outside the stated range (above it).
By their numbers in this assay, from the lowest: compound 2; then compound 1; then compound 3.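

The aryl ring on the sulfonyl sulfur tolerates much larger swings than the first pair suggested: in this assay, replacing 3-bromophenyl with 2,4-difluorophenyl gives a 32-fold higher number from compound 2 to compound 3 (1.50 log units; beyond the scatter), a large step where the only earlier one was modest. Set against the other bromine-bearing ring, the same kind of swap gives an 8.5-fold higher number from compound 1 to compound 3 (0.93 log units; beyond the scatter), so both compounds with bromine on this ring stand ahead of the difluoro compound. Among the compounds shown here, nothing at hand explains why this change moves the number so far.

This swap removes bromine and brings in two fluorines in a single move, leaving open which of the two matters more. Going by these compounds, how a 3-chlorophenyl ring, or a ring bearing an amine or a carboxylic acid, would behave at this place also remains open.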